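The compounds below may be only part of what the source reports. "The series", "measured", "known", "first", "only" and "open" are said of these compounds alone.

Measured so far:
compound 1, `Cc1cc(C)c(NC(=O)N(Cc2cccc(-n3cccc3)c2)C2CCCCCC2)c(C)c1`, 20 nM
compound 2, `Cc1cc(C)c(NC(=O)N(Cc2cccc(-c3ccn(C)n3)c2)C2CCCCCC2)c(C)c1`, 42 nM

Within the data shown here, in an assay on microsomes from intestine for inhibition of acyl-CoA:cholesterol acyltransferase (Oryctolagus cuniculus) (a lower number here means a stronger inhibitor, a higher number a weaker inhibitor), compound 2 stands as the higher of the two numbers measured; its nearest neighbour is compound 1, reached by the single step known here, a 2.1-fold higher number from compound 1 to compound 2 (0.32 log units; beyond the scatter). Compound 3, `Cc1cc(C)c(NC(=O)N(Cc2cccc(-c3ccnn3C)c2)C2CCCCCC2)c(C)c1`, differs from compound 2 only in how the same atoms are joined: 1-methyl-1H-pyrazol-5-yl in place of 1-methyl-1H-pyrazol-3-yl on an aromatic carbon. The change sits meta to a large group, on an aromatic carbon. Among the measured compounds shown here, no measured step mirrors this exchange; the one step available, a 2.1-fold higher number from compound 1 to compound 2 (0.32 log units; beyond the scatter), concerns a different ring entering the same place and is modest in size, so it bears on compound 3 only loosely. On that basis a step in this assay from compound 2 to compound 3 of no more than the scatter is expected, direction uncertain, written as a 1.2-fold higher number from compound 2 to compound 3 (0.08 log units; within the scatter). For compound 3 the value in this assay is therefore estimated at 50 nM, within the range 20 nM to 130 nM.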

Compound 3, half-maximal inhibitory concentration: 35 nM
For compound 3 the middle estimate is 1.4-fold (0.15 log units) above the measured one; low and high end bracket the measured number.
By their numbers in this assay, from the lowest: compounds 1, 3 and 2 (each within the scatter of the next, the first and the last beyond it).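

In this assay the exchange of 1-methyl-1H-pyrazol-3-yl for 1-methyl-1H-pyrazol-5-yl, on an aromatic carbon meta to a large group, gives a 1.2-fold lower number from compound 2 to compound 3 (0.08 log units; within the scatter) and so does not separate these two ways of joining the same atoms. Putting 1-methyl-1H-pyrazol-5-yl in place of 1H-pyrrol-1-yl gives a 1.8-fold higher number from compound 1 to compound 3 (0.24 log units; within the scatter) and stays within the scatter, whereas a 2.1-fold higher number from compound 1 to compound 2 (0.32 log units; beyond the scatter) lay just beyond it, so the earlier step does not hold for both methylpyrazolyl groups at this place. Nothing given here accounts for these numbers.

Open, going by these compounds, is whether an unmethylated pyrazole, a pyridine or a carboxylic acid at this place would keep the number in the same range in this assay as these rings do. Also open, on these data alone, is whether the two methylpyrazolyl groups would still read alike on a different core.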